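Azetidin-1-yl in place of allylamino on the shared core

The compounds below may be only part of what the source reports. "The series", "measured", "known", "first", "only" and "open" are said of these compounds alone.

Of the compounds shown here, two have so far been measured in a functional assay on SK-BR-3 cells (Homo sapiens) for cytotoxicity, read by CellTiter-Glo, with a stated time of 72 h (on this read-out lower numbers stand for stronger inhibition and higher numbers for weaker inhibition), for this series. Compound 1 (`C=CCNC1=C2C[C@@H](C)C[C@H](OC)C(=O)[C@@H](C)/C=C(\C)[C@H](OC(N)=O)[C@@H](OC)/C=C\C=C(/C)C(=O)NC(=CC1=O)C2=O`) gives 450 nM and compound 2 (`C=CCO/N=C1/[C@@H](OC)C[C@H](C)CC2=C(NCCN(C)C)C(=O)C=C(NC(=O)/C(C)=C/C=C\[C@H](OC)[C@@H](OC(N)=O)/C(C)=C/[C@@H]1C)C2=O`) gives 400 nM in this test. Among the measured compounds shown here, the two numbers lie within the scatter of each other, so compound 1 stands level with the only other measured compound.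

Compound 3 (`CO[C@H]1C[C@H](C)CC2=C(N3CCC3)C(=O)C=C(NC(=O)/C(C)=C/C=C\[C@H](OC)[C@@H](OC(N)=O)/C(C)=C/[C@H](C)C1=O)C2=O`) has not yet been measured. It keeps the core of compound 1 but carries azetidin-1-yl in place of allylamino on a double-bonded ring carbon. The entering group is a four-membered non-aromatic ring, whereas the leaving group has no ring.

For the measured compounds named here, no measured pair differs in one place only, so the data give no direct size for such a change. Going by the values given here, the only guide is how closely compound 1 at 450 nM and compound 2 at 400 nM agree, which is thin support. In this assay no step beyond the scatter is expected in either direction, and the estimated change is a 1.1-fold higher number from compound 1 to compound 3 (0.05 log units; within the scatter) on this swap. Compound 3 is expected at 500 nM with a range from 180 nM to 1400 nM in this estimate.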

Compound 3, half-maximal inhibitory concentration: 260 nM
Beside the measured number, compound 3's estimate is 1.9-fold (0.28 log units) above it; the measured number falls inside the stated range.
By their numbers in this assay, from the lowest: compounds 3, 2 and 1 (each within the scatter of the next).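

In this assay, putting azetidin-1-yl in place of allylamino on a double-bonded ring carbon gives a 1.7-fold lower number from compound 1 to compound 3 (0.24 log units; within the scatter) and this step lies within the scatter. Among the compounds shown here, this is the first single-place comparison, and it shows that the read-out stays within the scatter when this open chain with one hydrogen-bond donor gives way to a four-membered non-aromatic ring with none, at the same count of heavy atoms. No supporting data are available to explain this result.

The compounds shown leave open whether the same tolerance extends to larger rings on this carbon, such as pyrrolidin-1-yl, piperidin-1-yl or morpholin-4-yl, or to an open-chain dimethylamino group, which also has no hydrogen-bond donor. They also leave open whether azetidin-1-yl would behave the same way on a core carrying the other changes seen in compound 2, since this single step comes from one pair on the core of compound 1.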